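Trimming a Diol Side Chain on a Weak Antagonist

The source may hold more compounds than are shown below. What is called first, only, known or untested is meant among the compounds shown, and "the series" means these compounds.

Compound 1 `Cc1cc(CNC(=O)Nc2cc(Cl)nc(OCC(F)F)c2)nnc1-c1cn(C)nc1C(F)(F)F` gives 71000 nM in a functional assay on HFL1 cells for antagonist activity at sphingosine 1-phosphate receptor 2 (Homo sapiens), read by ELISA, with a stated time of 24 h, in the presence of a further agent that is not named here; on this read-out higher numbers stand for weaker inhibition and lower numbers for stronger inhibition.
Compound 2 `CCOc1cc(NC(=O)NCc2cc(C)c(-c3cn(C)nc3C(F)(F)F)nn2)cc(C)n1` gives 194000 nM in this assay.
Compound 3 `Cc1cc(CNC(=O)Nc2cc(OCC(O)CO)nc(C(F)(F)F)c2)nnc1-c1cn(C)nc1C(F)(F)F` gives only the limit > 10000000 nM in this assay.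

Compound 3 thus sits at the weakest end of the numbers shown, where (the limit of > 10000000 nM in this assay, at which 1 of the 3 values shown sits), and it is the only one that gives no number at all. Compound 4 `Cc1cc(CNC(=O)Nc2cc(OCCO)nc(C(F)(F)F)c2)nnc1-c1cn(C)nc1C(F)(F)F` differs from it by hydrogen in place of hydroxymethyl on a saturated chain carbon bound to an oxygen on a saturated carbon and a saturated chain carbon, which shortens the 2,3-dihydroxypropoxy group to a 2-hydroxyethoxy group. For the measured compounds named here, no measured pair shows this change. Compound 1 and compound 2 carry other alkoxy groups and both sit well inside the measurable range, so compound 4 is expected to move toward lower numbers in this assay, though its size cannot be set from a limit. Compound 4 is estimated at 3000000 nM, between 300000 nM and 10000000 nM, a step of an at least 3.3-fold lower number from compound 3 to compound 4 (0.52 log units; beyond the scatter).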

Compound 4, half-maximal inhibitory concentration: 810000 nM
The estimate for compound 4 lay 3.7-fold (0.57 log units) above the measured number, within the range that was stated.
By their numbers in this assay, from the lowest: compound 1; then compound 2; then compound 4. At a limit, above all of these: compound 3.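

Hydrogen in place of hydroxymethyl on this saturated chain carbon gives an at least 12-fold lower number from compound 3 to compound 4 (1.09 log units; beyond the scatter) in this assay, the first change in one place among the compounds shown. It shows that trimming 2,3-dihydroxypropoxy to 2-hydroxyethoxy brings the compound from a limit to a measurable number. Compound 3 stands at a limit, so the size of this step is only a bound: the limit of > 10000000 nM in this assay, at which 1 of the 4 values shown sits.

The compounds shown leave open whether a 2-aminoethoxy group in this place would move the number further. They also leave open what a longer chain ending in a carboxylic acid would do.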